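This account rests on a few compounds, and the source may have more. Where it says the series, first, only, none or still open, it means among the compounds named here.

Working notes on the amide series built on the shared core of compound 1 `O=C(CC1CCCC1)Nc1c(C(O)(C(F)(F)F)C(F)(F)F)ccc2ccccc12`. In an assay on LtK cells with ATP-sensitive inward rectifier potassium channel 11 (Homo sapiens) as the target (a higher number here means that more compound is needed for the effect, a lower number that less compound is needed), compound 1 gives 81 nM. Compound 2 `O=C(CCc1ccccc1)Nc1c(C(O)(C(F)(F)F)C(F)(F)F)ccc2ccccc12` gives 1750 nM in this assay, the step being a 22-fold higher number from compound 1 to compound 2 (1.33 log units; beyond the scatter). Compound 3 `O=C(Nc1c(C(O)(C(F)(F)F)C(F)(F)F)ccc2ccccc12)c1cccc([N+](=O)[O-])c1` gives 117 nM in this assay; the step of a 1.4-fold higher number from compound 1 to compound 3 (0.16 log units; within the scatter) places compound 3 alongside compound 1 among the lower numbers, while a 15-fold lower number from compound 2 to compound 3 (1.17 log units; beyond the scatter) sets it well apart from compound 2. Compound 4 `O=C(Nc1c(C(O)(C(F)(F)F)C(F)(F)F)ccc2ccccc12)c1cccnc1` is not yet measured. Its change from compound 3: pyridin-3-yl in place of 3-nitrophenyl on a carbonyl carbon. Going by the values given here, the steps that bear on this, a 1.4-fold higher number from compound 1 to compound 3 (0.16 log units; within the scatter) and a 15-fold lower number from compound 2 to compound 3 (1.17 log units; beyond the scatter), swap the whole group on the carbonyl carbon; no measured pair exchanges one aromatic ring for another. For compound 4 a modest step toward a somewhat higher number is therefore expected, a 1.7-fold higher number from compound 3 to compound 4 (0.23 log units; within the scatter). Compound 4 is estimated at 200 nM, in the range 60 nM to 700 nM.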

Compound 4, half-maximal effective concentration: 60 nM
Compound 4: the middle estimate sits 3.3-fold (0.52 log units) above what was measured; the range from low to high includes it.
By their numbers in this assay, from the lowest: compounds 4, 1 and 3 (each within the scatter of the next); then compound 2.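

Going by these compounds alone, the first direct exchange of one aromatic ring for another on the carbonyl carbon, pyridin-3-yl in place of 3-nitrophenyl, gives a 2.0-fold lower number from compound 3 to compound 4 (0.29 log units; within the scatter) in this assay, so this swap is not resolved by the assay. The cyclopentylmethyl comparison gives a 1.4-fold lower number from compound 1 to compound 4 (0.13 log units; within the scatter), whereas the phenethyl comparison gives a 29-fold lower number from compound 2 to compound 4 (1.46 log units; beyond the scatter), leaving compound 2 alone at the high end among these four. No measured evidence bearing on these steps is available.

Still open, as far as these compounds go, is how an unsubstituted phenyl or a benzoic acid group would read on this carbonyl carbon.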